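This account rests on a few compounds, and the source may have more. Where it says the series, first, only, none or still open, it means among the compounds named here.

Measured in a functional assay on the whole organism with Mus musculus as the target, in the rotarod test; a higher number here means that more compound is needed for the effect, a lower number that less compound is needed:
- compound 1 `CC(C)C(=O)NCC(=O)N(C)c1ccc(Cl)cc1C(=O)c1ccccc1Cl`: > 100 mg/kg (a limit of the assay, not a number)
- compound 2 `CCCC(=O)NCC(=O)N(C)c1ccc(Cl)cc1C(=O)c1ccccc1Cl`: 55.2 mg/kg

Among the compounds with values here, compound 2, at 55.2 mg/kg, holds the only true number so far. The other entry is the limit of > 100 mg/kg in this assay, at which 1 of the 2 values shown sits, and it belongs to compound 1.

Compound 3 `CCN(CC)CC(=O)NCC(=O)N(C)c1ccc(Cl)cc1C(=O)c1ccccc1Cl` has diethylamino in place of ethyl on a saturated chain carbon bound to a carbonyl carbon.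

Within the data shown here, only one measured step bears on this change, and it concerns the same acyl end of the molecule: an at least 1.8-fold lower number from compound 1 to compound 2 (0.25 log units; that floor lies within the scatter). That step replaces isopropyl with propyl, so it is only an indirect guide to adding diethylamino. Its size is a floor set by a limit, and that floor lies within the scatter. It therefore gives no firm basis for a direction, and no step beyond the scatter is expected in this assay. The expected step is a 1.1-fold higher number from compound 2 to compound 3 (0.04 log units; within the scatter), with wide uncertainty. The assay may also report only a limit for the new compound.

For compound 3 the estimated value is 60 mg/kg, with an expected range from 20 mg/kg to 180 mg/kg.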

Compound 3, dose for half-maximal effect: 34 mg/kg
Beside the measured number, compound 3's estimate is 1.8-fold (0.25 log units) above it, within the range that was stated.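

In this assay, putting diethylamino in place of ethyl on a saturated chain carbon bound to a carbonyl carbon gives a 1.6-fold lower number from compound 2 to compound 3 (0.21 log units; within the scatter), so this position accepts a larger group carrying a nitrogen with no change that can be told from the scatter. Within the data shown here, the other comparison, which sets (diethylamino)methyl against isopropyl on a carbonyl carbon, gives an at least 2.9-fold lower number from compound 1 to compound 3 (0.46 log units; beyond the scatter), and this is the first step that clears the scatter, whereas the floor of the earlier step from the isopropyl compound did not. Its size is still only a floor, since compound 1 holds a limit of the assay and not a number: the limit of > 100 mg/kg in this assay, at which 1 of the 3 values shown sits.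

With a single amine on this chain, the compounds shown leave open whether the nitrogen or the added carbon atoms matter here, which dimethylamino, piperidine or a plain pentyl chain in the same place could help to separate. Also open, as far as these compounds go, is how a carboxylic acid at this position, or a longer chain between the amine and the carbonyl, would read in this assay.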